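Replacing dimethylamino with ethoxycarbonyl: compound 3 to compound 4

The source may report more compounds than this note shows. Statements on the series, on what has been measured and on what is new or still open speak of the compounds shown alone.

compound 1 `CCOC(=O)C(=O)Nc1nc(-c2ccc(F)cc2)cs1`: > 10 mg/kg
compound 2 `CCOC(=O)C(=O)Nc1nc(-c2ccc(Oc3ccccc3)cc2)cs1`: > 30 mg/kg
compound 3 `CCOC(=O)C(=O)Nc1nc(-c2ccc(N(C)C)cc2)cs1`: about 1 mg/kg

These three compounds were tested in a functional assay on the whole organism with Rattus norvegicus as the target; a higher number here means that more compound is needed for the effect, a lower number that less compound is needed. Compound 1 gives > 10 mg/kg, which is a limit of the assay and not a number. Compound 2 gives > 30 mg/kg, which is likewise a limit. Compound 3, at about 1 mg/kg, is the only one of the three with an actual number, and it needs less compound than the other two.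

Compound 4 `CCOC(=O)C(=O)Nc1nc(-c2ccc(C(=O)OCC)cc2)cs1` has not yet been measured. It carries ethoxycarbonyl in place of dimethylamino on an aromatic carbon, para to a large group: ethoxycarbonyl in place of dimethylamino on an aromatic carbon.

Going by the values given here, two measured steps bear on this change: an at least 10-fold lower number from compound 1 to compound 3 (1.00 log units; beyond the scatter), and an at least 30-fold lower number from compound 2 to compound 3 (1.47 log units; beyond the scatter). In both, dimethylamino replaces another group at this same place, and both lie beyond the scatter. The third, a step that the two limits leave unreadable from compound 1 to compound 2, adds little. Among these three compounds, dimethylamino is the only group that gave a number, though ethoxycarbonyl itself has not been tested.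

Leaving dimethylamino is therefore expected to raise the number, and the expected change is a 15-fold higher number from compound 3 to compound 4 (1.18 log units; beyond the scatter). A limit rather than a number is a real possibility. For compound 4 the estimate is 15 mg/kg, with an expected range from 3 mg/kg to 60 mg/kg.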

Compound 4, dose for half-maximal effect: > 10 mg/kg
Compound 4: no number, only a limit; the forecaster's own chance of this, stated with the estimate: 50%; the middle value does not contradict the limit.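

In this assay, going by these compounds alone, ethoxycarbonyl in place of dimethylamino gives an at least 10-fold higher number from compound 3 to compound 4 (1.00 log units; beyond the scatter), so this is the first direct measure of what leaving dimethylamino costs when the incoming group is neither fluoro nor phenoxy. With a third different group at this aromatic carbon failing to give a number, dimethylamino remains the only one of the four groups shown that does, and the pattern has no exception among compounds 1 to 4. Compound 4 has only a limit of the assay and no number: the limit of > 10 mg/kg in this assay, at which 2 of the 4 values shown sit.

The steps from compound 2 and from compound 1 to compound 4 join two limits and cannot be read, so fluoro, phenoxy and ethoxycarbonyl cannot be placed in order against one another. As far as these compounds go, it remains open whether the low number of compound 3 belongs to dimethylamino alone or extends to other amines at this place, such as an unsubstituted amine, diethylamino or morpholine, and how far compound 4 lies beyond its limit.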